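Changing the Amide Aryl Group in a Histone Deacetylase 8 Series

The source may report more compounds than this note shows. Statements on the series, on what has been measured and on what is new or still open speak of the compounds shown alone.

Compound 1 `O=C(COc1ccc2cc(/C=C3/SC(=O)NC3=O)ccc2c1)Nc1cc(Cl)cc(C(F)(F)F)c1` gives > 50000 nM in an assay on isolated protein for inhibition of histone deacetylase 8 (Homo sapiens), with a stated time of 1 h; on this read-out lower numbers stand for stronger inhibition and higher numbers for weaker inhibition; this is a limit of the assay, not a number.
Compound 2 `O=C(COc1ccc2cc(/C=C3/SC(=O)NC3=O)ccc2c1)Nc1ccccn1` gives > 50000 nM in this assay; again a limit.
Compound 3 `O=C(COc1ccc2cc(/C=C3/SC(=O)NC3=O)ccc2c1)Nc1ccc(Cl)c(Cl)c1` gives > 50000 nM in this assay; again a limit.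

Compound 3 thus stands where every measured compound stands, at the limit of > 50000 nM in this assay, at which 3 of the 3 values shown sit. The steps a step that the two limits leave unreadable from compound 1 to compound 2, a step that the two limits leave unreadable from compound 1 to compound 3 and a step that the two limits leave unreadable from compound 2 to compound 3 cannot be sized because both ends sit at the limit of > 50000 nM in this assay, at which 3 of the 3 values shown sit.

Compound 4 `O=C(COc1ccc2cc(/C=C3/SC(=O)NC3=O)ccc2c1)Nc1ccc([N+](=O)[O-])cc1` differs from compound 3 by 4-nitrophenyl in place of 3,4-dichlorophenyl on an amide-type nitrogen. All three measured steps change the group on the same amide-type nitrogen, yet none shows a readable size, so no direction can be drawn from them. Compound 4 is therefore expected to stay at the limit, a step that the limit leaves unreadable from compound 3 to compound 4, and its value in this assay is estimated at 60000 nM, within 20000 nM to 200000 nM.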

Compound 4, half-maximal inhibitory concentration: 4000 nM
Estimate against measurement, compound 4: 15-fold (1.18 log units) above, and the stated range ends above it.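

Replacing the earlier groups with 4-nitrophenyl gives an at least 12-fold lower number from compound 3 to compound 4 (1.09 log units; beyond the scatter) and an at least 12-fold lower number from compound 2 to compound 4 (1.09 log units; beyond the scatter) and an at least 12-fold lower number from compound 1 to compound 4 (1.09 log units; beyond the scatter) in this assay on the shared core. For the compounds shown here, the group on this amide-type nitrogen can therefore bring the series to a readable value, which the earlier compounds could not show. Compound 4 alone gives such a value, and the true steps could be larger since their other ends are limits: the limit of > 50000 nM in this assay, at which 3 of the 4 values shown sit.

From the compounds shown here alone, whether the nitro group itself is what counts stays open. So does the outcome with a 4-aminophenyl or 4-carboxyphenyl group on the same nitrogen.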